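The source may report more compounds than this note shows. Statements on the series, on what has been measured and on what is new or still open speak of the compounds shown alone.

Compound 1 `Cc1ccc(C(=O)N2CCN(CC(=O)N3CCN(CCCc4c[nH]c5ccccc45)CC3)CC2)cc1` gives in an ADME assay on SH-SY5Y cells (Homo sapiens) for cytotoxicity, read by MTT assay, with a stated time of 72 h (a lower number here means a stronger inhibitor, a higher number a weaker inhibitor), only a limit of the assay, > 200000 nM. Compound 2 `O=C(CN1CCN(C(=O)c2ccc(F)cc2)CC1)N1CCN(CCCc2c[nH]c3ccccc23)CC1` gives in this assay a value of 188000 nM. Compound 3 `COc1ccc2[nH]cc(CCCN3CCN(C(=O)CN4CCN(C(=O)c5ccc(C)cc5)CC4)CC3)c2c1` gives in this assay only a limit, > 200000 nM.

Compounds 1 and 2 share one core and differ by fluoro in place of methyl on an aromatic carbon. In this assay this change made an at least 1.0-fold lower number from compound 1 to compound 2 (0.02 log units; that floor lies within the scatter), so the two compounds cannot be told apart. Compounds 1 and 3 differ in the core by methoxy in place of hydrogen on an aromatic carbon; for that pair a step that the two limits leave unreadable from compound 1 to compound 3, because the limit of > 200000 nM in this assay, at which 2 of the 3 values shown sit, leaves both ends unreadable, and the difference between the cores is otherwise not broken down here.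

The unmeasured compound 4 `COc1ccc2[nH]cc(CCCN3CCN(C(=O)CN4CCN(C(=O)c5ccc(F)cc5)CC4)CC3)c2c1` carries the core of compound 3 and differs from it by fluoro in place of methyl on an aromatic carbon. This is the same change as that from compound 1 to compound 2, and it sits in the same place. Since that change gave an at least 1.0-fold lower number from compound 1 to compound 2 (0.02 log units; that floor lies within the scatter) and compound 3 stands at a limit, compound 4 is expected to sit near the same limit, with an expected step of a number no higher from compound 3 to compound 4 (the limit leaves the size open). Compound 4 is therefore estimated at 200000 nM in this assay, and the expected range runs from 120000 nM to 400000 nM, with a good chance that only a limit is reported.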

Compound 4, half-maximal inhibitory concentration: > 200000 nM
Compound 4: no number, only a limit; the forecaster's own chance of this, stated with the estimate: 60%; the middle value lies on the limit itself.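

Carried onto the core of compound 3, the change of methyl to fluoro gives compound 4, which again reaches only a limit of the assay, and the steps that end at a limit on both sides cannot be read, since neither end is a number: the limit of > 200000 nM in this assay, at which 3 of the 4 values shown sit. Within the data shown here, the one readable new step, that of the methoxy group in place of hydrogen, is an at least 1.0-fold higher number from compound 2 to compound 4 (0.02 log units; that floor lies within the scatter), so the two compounds cannot be told apart in this assay. The series thus shows that the change of methyl to fluoro gave no separable value on the core of compound 1 and no readable number on the core of compound 3, but it does not show that the change acts alike on both cores, as one step has only a floor and the other has no size at all.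

The compounds shown leave open whether any group at this place on the ring would give a number clearly lower than those seen here. An amine or a carboxylic acid in place of the fluoro of the 4-fluorophenyl, or a longer chain in place of the methyl of the 4-methylphenyl, would be one way to test that in this assay.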